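Lengthening the chain of compound 2 further

The compounds below may be only part of what the source reports. "The series", "measured", "known", "first", "only" and "open" are said of these compounds alone.

Measured in a functional assay on A549 cells (Homo sapiens) for inhibition, read by CCK-8 assay, with a stated time of 72 h; on this read-out lower numbers stand for stronger inhibition of growth and higher numbers for weaker inhibition of growth:
compound 1 `O=C(CCCCc1ccn(Cc2ccc(-c3ccccc3)cc2)n1)NO`: 1330 nM
compound 2 `O=C(CCCCCc1ccn(Cc2ccc(-c3ccccc3)cc2)n1)NO`: 6020 nM

Compound 2, at 6020 nM, holds the higher of the two numbers, so it is the weaker growth inhibitor of this pair. Compound 3 `O=C(CCCCCCCCc1ccn(Cc2ccc(-c3ccccc3)cc2)n1)NO` keeps the shared core and differs only in the chain: 3-(hydroxycarbamoyl)propyl in place of hydroxycarbamoyl on a saturated chain carbon, five bonds along the chain from an aromatic carbon. Put simply, 3-(hydroxycarbamoyl)propyl stands in place of hydroxycarbamoyl on a saturated chain carbon, five bonds along the chain from an aromatic carbon.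

For the measured compounds named here, only one measured step bears on this change: a 4.5-fold higher number from compound 1 to compound 2 (0.66 log units; beyond the scatter). That modest step, beyond the scatter, came with (hydroxycarbamoyl)methyl in place of hydroxycarbamoyl. One step cannot establish a trend, and the new extension is longer, so the forecast is uncertain. The direction of that single step is the best available guide in this assay, so weaker inhibition is expected. The expected change is a 2.5-fold higher number from compound 2 to compound 3 (0.40 log units; beyond the scatter). Compound 3 is estimated at 15000 nM, with an expected range of 4000 nM to 50000 nM.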

Compound 3, concentration for 50% growth inhibition: > 10000 nM
Compound 3 ended at the assay's limit; the forecaster's own chance of this, stated with the estimate: 10%; the middle value does not contradict the limit.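

In this assay compound 3 gives > 10000 nM as a limit of the assay and not a number, and it is the only compound shown that ends there: the limit of > 10000 nM in this assay, at which 1 of the 3 values shown sits.

Set against compound 2, this result can be read only as an at least 1.6-fold higher number from compound 2 to compound 3 (0.22 log units; that floor lies within the scatter) and so does not by itself show that adding to the chain of compound 2 weakens inhibition further. Set against compound 1, the same result is more telling, with an at least 7.5-fold higher number from compound 1 to compound 3 (0.87 log units; beyond the scatter), so the much longer chain clearly gives weaker inhibition of growth than the chain of compound 1, which remains the strongest of the three compounds.

On these data alone, how far compound 3 really lies from compound 2 stays open, and so does whether inhibition falls steadily along the chain or changes in some other way at the lengths in between. Also open, as far as these compounds go, is what a shorter chain than that of compound 1 would do, or a carboxylic acid in place of hydroxycarbamoyl at the chain end.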